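Carboxy for dimethylamino on the chlorobenzoyl series

A few compounds are considered here, and "the series" means these few. Any claim that something is new, unique, unknown or untested is made for them only; others in the source may bear on it.

Measured so far:
compound 1, `Nc1sc(-c2ccc(C(=O)O)cc2)cc1C(=O)c1ccccc1`: 27%
compound 2, `CN(C)c1ccc(-c2cc(C(=O)c3ccc(Cl)cc3)c(N)s2)cc1`: 41%

Two compounds of the shared core have been run in an assay on CHO cells for positive allosteric modulation of adenosine receptor A1 (Homo sapiens), read by ERK phosphorylation, tested at 10 uM; a higher number here means a weaker effect of the compound at the concentration tested, a lower number a stronger effect. Compound 1 gives 27%, and compound 2 gives 41%, the highest of the two numbers; the gap of compound 2 to compound 1 lies beyond the scatter, so compound 2 shows the weaker effect of the pair.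

The next step goes from compound 2 to compound 3, `Nc1sc(-c2ccc(C(=O)O)cc2)cc1C(=O)c1ccc(Cl)cc1`, not yet measured. The change is carboxy in place of dimethylamino on an aromatic carbon, on an aromatic carbon of a six-membered aromatic ring of carbon only, para to a large group.

Going by the values given here, no measured pair differs in exactly this way, so the step size is open. A drop toward the lower number is expected, because compound 1, which also carries a carboxy group, gives 27%. For compound 3 the estimate is 30%, within 18% to 44%. The expected step of a number 11 percentage points lower from compound 2 to compound 3 (beyond the scatter) would be a fall beyond the scatter.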

Compound 3, a percentage reported as activity, at one concentration (the size of the read-out at that concentration, not a potency): 29%
Beside the measured number, compound 3's estimate is 1 percentage points above it; the measured number falls inside the stated range.
By their numbers in this assay, from the lowest: compounds 1 and 3 (each within the scatter of the next); then compound 2.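

Within this assay the new compound gives the first direct reading at this position: carboxy in place of dimethylamino on an aromatic carbon, para to a large group, gives a number 12 percentage points lower from compound 2 to compound 3 (beyond the scatter) on the chlorobenzoyl series. Going by these compounds alone, it also gives the first reading of the chloro group, since chloro in place of hydrogen on an aromatic carbon gives a number 2 percentage points higher from compound 1 to compound 3 (within the scatter) with carboxy held constant, so the two carboxy compounds cannot be told apart here. No measurement at hand explains either step.

On these data alone, whether a primary amide or a methyl ester on the same carbon would read with the carboxy compounds or with compound 2 remains open. Also open, as far as these compounds go, is whether chloro in place of hydrogen would matter with dimethylamino at this position.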